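The source may hold more compounds than are shown below. What is called first, only, known or untested is meant among the compounds shown, and "the series" means these compounds.

Compound 1 `CCSc1nnc(COc2cc(C)c3c(C)cc(=O)oc3c2)o1` reports only a limit in a functional assay on MCF7 cells (Homo sapiens) for antiproliferative activity, read by MTT assay, with a stated time of 24 h (on this read-out lower numbers stand for stronger inhibition and higher numbers for weaker inhibition), namely > 100000 nM. Compound 2 `CCCCSc1nnc(COc2cc(C)c3c(C)cc(=O)oc3c2)o1` likewise reports only a limit, > 100000 nM. The step that the two limits leave unreadable from compound 1 to compound 2 cannot be sized, since both values sit at the limit of > 100000 nM in this assay, at which 2 of the 2 values shown sit. Compound 3 `CCCCCSc1nnc(COc2cc(C)c3c(C)cc(=O)oc3c2)o1` differs from compound 1 by propyl in place of hydrogen on a saturated chain carbon, two bonds along the chain from a sulfur. The only measured step bearing on this change is unreadable, so no direction or size is set for this assay from the numbers shown. Compound 3 is expected to remain at the limit, an estimated step that the limit leaves unreadable from compound 1 to compound 3. The estimate for compound 3 is 150000 nM, within 30000 nM to 1000000 nM, most probably reported only as a limit.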

Compound 3, half-maximal inhibitory concentration: > 100000 nM
Compound 3 ended at the assay's limit (the forecaster's own chance of this, stated with the estimate: 85%); the middle value is on the limit's open side.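

No new step can be read among compound 1, compound 2 and compound 3, since each gives only a limit: the limit of > 100000 nM in this assay, at which 3 of the 3 values shown sit. The compounds shown leave open whether any chain on the sulfur gives a readable value in this assay.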